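From trifluoromethyl to ethoxy on the aromatic ring

This account rests on a few compounds, and the source may have more. Where it says the series, first, only, none or still open, it means among the compounds named here.

Measured in a functional assay on KB cells (Homo sapiens) for antiproliferative activity, read by sulforhodamine B assay, with a stated time of 3 days; a higher number here means that more compound is needed for the effect, a lower number that less compound is needed:
Compound 1 `CCC1=C(O)c2c(oc(-c3ccc(C(C)C)cc3)cc2=O)C(CC)(CC)C1=O`: 8.13 uM
Compound 2 `CCCCc1ccc(-c2cc(=O)c3c(o2)C(CC)(CC)C(=O)C(CC)=C3O)cc1`: 111 uM
Compound 3 `CCC1=C(O)c2c(oc(-c3ccc(C(F)(F)F)cc3)cc2=O)C(CC)(CC)C1=O`: 35.7 uM

The middle place among these three numbers falls to compound 3. Its neighbours are set by a 4.4-fold higher number from compound 1 to compound 3 (0.64 log units; beyond the scatter) and by a 3.1-fold lower number from compound 2 to compound 3 (0.49 log units; beyond the scatter). Compound 4 `CCOc1ccc(-c2cc(=O)c3c(o2)C(CC)(CC)C(=O)C(CC)=C3O)cc1` carries ethoxy in place of trifluoromethyl on an aromatic carbon, para to a large group: ethoxy in place of trifluoromethyl on an aromatic carbon. Going by the values given here, all the measured steps are changes at this carbon, and they run in both directions, the largest being a 14-fold higher number from compound 1 to compound 2 (1.14 log units; beyond the scatter). None of them involves ethoxy, so no step beyond the scatter is expected in this assay, and the uncertainty stays wide. The expected step is a 1.2-fold lower number from compound 3 to compound 4 (0.08 log units; within the scatter). Compound 4 is estimated at 30 uM, with an expected range of 8 uM to 110 uM.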

Compound 4, concentration for half-maximal effect: > 52.4 uM
Compound 4: a limit, no number (the forecaster's own chance of this, stated with the estimate: 5%); at least 1.7-fold (0.24 log units) between middle value and limit.
By their numbers in this assay, from the lowest: compound 1; then compound 3; then compound 2.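

In this assay compound 4 gives a limit of the assay and not a number: the limit of > 52.4 uM in this assay, at which 1 of the 4 values shown sits. Ethoxy, the only group at this carbon with a hydrogen-bond acceptor, shows an at least 6.4-fold higher number from compound 1 to compound 4 (0.80 log units; beyond the scatter), so isopropyl keeps the lowest number of the four. The other two steps settle less: an at least 1.4-fold higher number from compound 3 to compound 4 (0.16 log units; that floor lies within the scatter) has a floor within the scatter, and the step from compound 2 to compound 4 cannot be read.

The compounds shown leave open where compound 4 would fall as a number. They also leave open how an amine or a carboxylic acid at this carbon would read.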